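Amide nitrogen substituent on the shared core

This account rests on a few compounds, and the source may have more. Where it says the series, first, only, none or still open, it means among the compounds named here.

Compound 1 `Cc1ccc2c(NN)c(Cc3ccccc3)cnc2n1` gives 220 nM in an assay for binding affinity to adenosine receptor A1 (Bos taurus); a higher number here means a weaker inhibitor, a lower number a stronger inhibitor. Compound 2 `Cc1ccc2c(O)c(C(=O)NN3CCOCC3)cnc2n1` gives only > 10000 nM in this assay, which is a limit of the assay and not a number (the limit of > 10000 nM in this assay, at which 1 of the 2 values shown sits). Compound 2 therefore stands at the limit among the values shown and has no number of its own. Compound 3 `Cc1ccc2c(O)c(C(=O)NCCC(C)C)cnc2n1` differs from compound 2 in one place: isopentyl in place of morpholin-4-yl on an amide-type nitrogen. Going by the values given here, no measured step covers this change; the expected step of an at least 1.2-fold lower number from compound 2 to compound 3 (0.09 log units; that floor lies within the scatter) is small and of uncertain direction, probably none beyond the scatter. Compound 3 is estimated at 8000 nM in this assay, between 2000 nM and 30000 nM.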

Compound 3, inhibition constant: > 10000 nM
Compound 3 ended at the assay's limit; the forecaster's own chance of this, stated with the estimate: 55%; middle value at least 1.2-fold (0.09 log units) from the limit.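

No step can be read from compound 2 to compound 3 in this assay, because both values are limits of the assay and not numbers: the limit of > 10000 nM in this assay, at which 2 of the 3 values shown sit.

On these data alone, whether isopentyl and morpholin-4-yl differ at all on this amide-type nitrogen stays open.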